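Swapping 3-bromophenyl for 4-chlorophenyl in a cytotoxicity series

A few compounds are considered here, and "the series" means these few. Any claim that something is new, unique, unknown or untested is made for them only; others in the source may bear on it.

- Compound 1 `COc1ccc(/C=C/C(=O)c2ccc(N)c(-c3ccc(F)cc3)c2)cc1O`: "not determined" (no result reported)
- Compound 2 `COc1ccc(/C=C/C(=O)c2cccc(-c3ccc(F)cc3)c2)cc1`: 16400 nM
- Compound 3 `O=C(/C=C/c1cccc(Br)c1)c1cccc(-c2cccc(F)c2)c1`: 12700 nM

All three compounds were taken to a functional assay on MCF7 cells (Homo sapiens) for cytotoxicity, read by sulforhodamine B assay, with a stated time of 48 h; on this read-out higher numbers stand for weaker inhibition and lower numbers for stronger inhibition. There, compound 3 at 12700 nM lies within the scatter of compound 2 at 16400 nM, and compound 1 has no number to compare. Compound 4 `O=C(/C=C/c1ccc(Cl)cc1)c1cccc(-c2cccc(F)c2)c1` is still to be measured in this assay. It differs from compound 3 as follows: 4-chlorophenyl in place of 3-bromophenyl on a double-bonded chain carbon bound to a double-bonded chain carbon. Going by the values given here, no measured pair shows what such an exchange does, so no change beyond the scatter is expected. The estimated step of a 1.0-fold higher number from compound 3 to compound 4 (0.01 log units; within the scatter) is correspondingly small, and the expectation stays anchored on compound 3 at 12700 nM. For compound 4 the expected value is 13000 nM, with an estimated range of 5500 nM to 30000 nM.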

Compound 4, half-maximal inhibitory concentration: 18200 nM
The estimate for compound 4 lay 1.4-fold (0.15 log units) below the measured number, within the range that was stated.
By their numbers in this assay, from the lowest: compounds 3, 2 and 4 (each within the scatter of the next).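

In this assay, 4-chlorophenyl in place of 3-bromophenyl on a double-bonded chain carbon bound to a double-bonded chain carbon gives a 1.4-fold higher number from compound 3 to compound 4 (0.16 log units; within the scatter) and so stays within the scatter. Going by these compounds alone, this is the first measured exchange at this position, and it shows that one halogen-bearing phenyl group can replace the other without a change that can be told from the scatter. Nothing measured here speaks to a cause for this result. Still open, going by these compounds, is whether an amine or a carboxylic acid on this phenyl group would shift the number beyond the scatter.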